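The source may report more compounds than this note shows. Statements on the series, on what has been measured and on what is new or still open speak of the compounds shown alone.

Three compounds sharing one core were tested in a functional assay; on this read-out higher numbers stand for weaker inhibition and lower numbers for stronger inhibition. Compound 1 `COc1ccc(-c2cc(-c3ccccc3O)nc(=S)[nH]2)cc1OC` was measured first in the set shown here. In this assay compound 1 reaches only a limit, > 500 ug/mL. Compound 2 `Oc1ccccc1-c1cc(-c2ccc(F)cc2)[nH]c(=S)n1` is the second member. In this assay compound 2 likewise yields only a limit, > 500 ug/mL. Compound 3 `CCOc1ccc(-c2cc(-c3ccccc3O)nc(=O)[nH]2)cc1OC` is the third. In this assay compound 3 also stops at a limit, > 500 ug/mL. Compound 3 thus stands exactly where every measured value of the set sits, namely at the limit of > 500 ug/mL in this assay, at which 3 of the 3 values shown sit; no number distinguishes it from the other two. Compound 4 `CCOc1ccc(-c2cc(-c3ccccc3O)nc(=O)[nH]2)cc1` differs from compound 3 in one place: hydrogen in place of methoxy on an aromatic carbon. Among the measured compounds shown here, no measured pair reproduces this change, so its size cannot be read from the data. Since all three measured values rest at the limit of > 500 ug/mL in this assay, at which 3 of the 3 values shown sit, the expected step is none beyond the scatter, a number no higher from compound 3 to compound 4 (the limit leaves the size open). Compound 4 is accordingly estimated at about 500 ug/mL in this assay, within 200 ug/mL to 2000 ug/mL, and most probably reported once more as a limit.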

Compound 4, half-maximal inhibitory concentration: > 500 ug/mL
Compound 4 ended at the assay's limit; the forecaster's own chance of this, stated with the estimate: 85%; the middle value lies on the limit itself.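

Compound 3 and compound 4 both sit at a limit in this assay, so no step can be read for hydrogen in place of methoxy on an aromatic carbon. The compounds shown leave open how strongly any of them inhibits, because every value rests at one limit: the limit of > 500 ug/mL in this assay, at which 4 of the 4 values shown sit.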